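The source may hold more compounds than are shown below. What is called first, only, known or untested is meant among the compounds shown, and "the series" means these compounds.

Measured so far:
compound 1 `Nc1cccc2c(-c3cccc(NC(=O)c4ccc5c(c4)OCCO5)c3)ccnc12` — 83 nM
compound 2 `CC(=O)Nc1cccc2c(-c3cccc(NC(=O)c4ccc(Cl)c(C(F)(F)F)c4)c3)ccnc12` — 3300 nM

In a functional assay on M14 cells (Homo sapiens) for antiproliferative activity, read by sulforhodamine B assay, with a stated time of 48 h (a lower number here means a stronger inhibitor, a higher number a weaker inhibitor), compound 1 gives 83 nM. Compound 2 gives 3300 nM in this assay, the highest of the two numbers, and the gap to compound 1 lies well beyond the scatter.

The next compound, compound 3 `CC(=O)Nc1cccc2c(-c3cccc(NC(=O)c4ccc5c(c4)OCCO5)c3)ccnc12`, is not yet measured. It differs from compound 2 in one place: 2,3-dihydro-1,4-benzodioxin-6-yl in place of 4-chloro-3-(trifluoromethyl)phenyl on a carbonyl carbon. Among the measured compounds shown here, the group that enters is the one carried by compound 1, whose value of 83 nM in this assay is the lower of the two known numbers, while the rest of compound 3 matches compound 2.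

For the measured compounds named here, no step between two measured compounds isolates this exchange. The expectation is that the step from compound 2 to compound 3 lowers the number, by a 5.5-fold lower number from compound 2 to compound 3 (0.74 log units; beyond the scatter), without reaching the level of compound 1. Compound 3 is thus estimated at 600 nM, within 150 nM to 2500 nM.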

Compound 3, half-maximal inhibitory concentration: 98 nM
Compound 3: the middle estimate sits 6.1-fold (0.79 log units) above what was measured; measured number outside the range, below it.
By their numbers in this assay, from the lowest: compounds 1 and 3 (each within the scatter of the next); then compound 2.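

In this assay, the exchange of 4-chloro-3-(trifluoromethyl)phenyl for 2,3-dihydro-1,4-benzodioxin-6-yl on a carbonyl carbon now stands alone, and it gives a 34-fold lower number from compound 2 to compound 3 (1.53 log units; beyond the scatter), so the group on this carbonyl carbon can carry a large step by itself. At the other place that differs, acetyl in place of hydrogen on a nitrogen on an aromatic ring gives a 1.2-fold higher number from compound 1 to compound 3 (0.07 log units; within the scatter), so with 2,3-dihydro-1,4-benzodioxin-6-yl on the carbonyl, this exchange does not separate the two compounds. No independent measurement bears on the reason for either step.

Whether the acetyl exchange reads the same with 4-chloro-3-(trifluoromethyl)phenyl on the carbonyl stays open, as the compounds shown hold no such pair. Also open, on these data alone, is how an unsubstituted phenyl or a methoxyphenyl on the carbonyl, or a longer acyl chain on the nitrogen, would compare.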